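Swapping the ring-nitrogen substituent on the shared core

The compounds below may be only part of what the source reports. "The series", "measured", "known", "first", "only" and "open" are said of these compounds alone.

Three compounds share one core and differ only in the group on an amine nitrogen in a ring. Compound 1 `CCCS(=O)(=O)N1CC=C(c2ccc3c(c2)CC(C2CCN(Cc4ccccc4)CC2)O3)CC1` carries a benzyl there, compound 2 `CCCS(=O)(=O)N1CC=C(c2ccc3c(c2)CC(C2CCN(C(=O)OC(C)C)CC2)O3)CC1` an isopropoxycarbonyl, and compound 3 `CCCS(=O)(=O)N1CC=C(c2ccc3c(c2)CC(C2CCN(S(=O)(=O)CCC)CC2)O3)CC1` a propylsulfonyl. In a functional assay on HEK293 cells with Glucose-dependent insulinotropic receptor (Homo sapiens) as the target, read by cAMP accumulation, with a stated time of 60 min (a higher number here means a larger maximal response, a lower number a smaller maximal response), compound 1 gives 88%, compound 2 gives 61%, and compound 3 gives 43%. Compound 3 stands lowest of the three: the step of a number 45 percentage points lower from compound 1 to compound 3 (beyond the scatter) is large, and the step of a number 18 percentage points lower from compound 2 to compound 3 (beyond the scatter) is modest, so both replacements that introduced the propylsulfonyl lowered the maximal response.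

Compound 4 `CCCS(=O)(=O)N1CC=C(c2ccc3c(c2)CC(C2CCN(c4ncc(C(F)(F)F)cn4)CC2)O3)CC1` changes this very position again (5-(trifluoromethyl)pyrimidin-2-yl in place of propylsulfonyl on an amine nitrogen in a ring). Among the compounds with values here, no measured step involves an aromatic group of this kind on that nitrogen, so the expectation rests on what the two steps into compound 3 show: leaving the propylsulfonyl for a different group raised the maximal response each time, by a modest to large amount. On that ground an upward step beyond the scatter is expected, though its size is uncertain because a number 18 percentage points lower from compound 2 to compound 3 (beyond the scatter) and a number 45 percentage points lower from compound 1 to compound 3 (beyond the scatter) differ so much. The expected step is a number 25 percentage points higher from compound 3 to compound 4 (beyond the scatter). Compound 4 is therefore estimated to reach 68% in this assay, with a range from 45% to 92%.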

Compound 4, largest response reached (Emax), in percent of the reference or control that the assay uses: 118%
For compound 4 the middle estimate is 50 percentage points below the measured one, outside the stated range (above it).
By their numbers in this assay, from the lowest: compound 3; then compound 2; then compound 1; then compound 4.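

In this assay, the 5-(trifluoromethyl)pyrimidin-2-yl on this amine nitrogen gives a far larger maximal response than the propylsulfonyl or the isopropoxycarbonyl, with a number 75 percentage points higher from compound 3 to compound 4 (beyond the scatter) and a number 57 percentage points higher from compound 2 to compound 4 (beyond the scatter). Within the data shown here, it also surpasses the benzyl, the best group among the earlier compounds, with a number 30 percentage points higher from compound 1 to compound 4 (beyond the scatter), so the benzyl does not mark the upper end of what this position can give, and changes here can raise the response as well as lower it. Nothing available explains why this group gives so much more than the other three.

Compound 4 carries the pyrimidine ring and the trifluoromethyl together, so the compounds shown leave open which of the two accounts for the gain, or whether both are needed. A plain pyrimidin-2-yl, which lacks the trifluoromethyl, or a phenyl ring bearing a trifluoromethyl, which lacks the ring nitrogens, would help to separate the two contributions.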